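The compounds below may be only part of what the source reports. "The series", "measured", "known", "first", "only" and "open" are said of these compounds alone.

Compound 2 `Nc1cccc(-c2cn3nc(-c4ccc(F)cc4)sc3n2)c1` reaches only a limit in a functional assay on L1210 cells (Mus musculus) for inhibition, read by cell counting, with a stated time of 2 days (a higher number here means a weaker inhibitor, a lower number a stronger inhibitor), giving >= 250000 nM; it is one of the values at the limit of >= 250000 nM in this assay, at which 1 of the 3 values shown sits. Compound 1 `C=C(Br)C(=O)Nc1cccc(-c2cn3c(-c4ccc(OC)cc4)csc3n2)c1` gives 200 nM in this assay, and compound 3 `C=C(Br)C(=O)Nc1cccc(-c2cn3nc(-c4ccc(F)cc4)sc3n2)c1` gives 250 nM. Among the compounds with values here, the single measured step starting from compound 2 is the addition of a (1-bromoethenyl)carbonyl group on a nitrogen, which brought an at least 1000-fold lower number from compound 2 to compound 3 (3.00 log units; beyond the scatter). Compound 4 `COc1ccc(-c2nn3cc(-c4cccc(N)c4)nc3s2)cc1` keeps the free nitrogen of compound 2 and differs from it only as follows: methoxy in place of fluoro on an aromatic carbon. Within the data shown here, compound 1 carries methoxy and compound 3 carries fluoro, and their two values lie close together, so no measured step bears on this swap. Compound 4 is therefore expected to remain at the limit, meaning a number no higher from compound 2 to compound 4 (the limit leaves the size open), with an estimate of 250000 nM and a range from 100000 nM to 500000 nM.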

Compound 4, half-maximal inhibitory concentration: >= 250000 nM
Compound 4: a limit, no number; the forecaster's own chance of this, stated with the estimate: 85%; the middle value lies on the limit itself.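

Compound 4, like compound 2, sits at a limit and not at a number, so the step between these two compounds cannot be read: the limit of >= 250000 nM in this assay, at which 2 of the 4 values shown sit.

From the compounds shown here alone, whether methoxy in place of fluoro on this free-nitrogen pair changes inhibition at all stays open.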